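Hydroxy in place of furan-2-yl: a para-position swap

The compounds below may be only part of what the source reports. "The series", "measured", "known", "first", "only" and "open" are said of these compounds alone.

Measured compounds:
compound 1 `SC1=NC(n2nc(-c3ccccc3)nc2-c2ccccc2)=CC(c2ccc(-c3ccccc3)cc2)N1` gives 100 mg/kg in a functional assay on the whole organism with Mus musculus as the target, in the maximal electroshock model, with a stated time of 0.5 h; a higher number here means that more compound is needed for the effect, a lower number that less compound is needed
compound 2 `SC1=NC(n2nc(-c3ccccc3)nc2-c2ccccc2)=CC(c2ccc(-c3ccco3)cc2)N1` gives 30 mg/kg in this assay

Among the measured compounds shown here, compound 2 stands at the lowest of the two numbers measured so far; the only measured step is the one that leads to it, a 3.3-fold lower number from compound 1 to compound 2 (0.52 log units; beyond the scatter). Compound 3 `Oc1ccc(C2C=C(n3nc(-c4ccccc4)nc3-c3ccccc3)N=C(S)N2)cc1` has not yet been measured. It differs from compound 2 as follows: hydroxy in place of furan-2-yl on an aromatic carbon. For the measured compounds named here, the change sits on an aromatic carbon of a six-membered aromatic ring of carbon only, para to a large group, the same place that was altered in the single measured step.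

That step, a 3.3-fold lower number from compound 1 to compound 2 (0.52 log units; beyond the scatter), shows that a change at this position can move the number beyond the scatter, but it compares phenyl with furan-2-yl, neither of which is hydroxy, so it sets no direction for compound 3. With furan-2-yl giving the lowest number and hydroxy being a far smaller group, a modest move back upward is the more likely outcome, though a number within the scatter of compound 2 cannot be excluded. Compound 3 is therefore expected at 55 mg/kg, between 20 mg/kg and 150 mg/kg, that is an estimated step of a 1.8-fold higher number from compound 2 to compound 3 (0.26 log units; within the scatter).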

Compound 3, minimum effective dose: 30 mg/kg
Compound 3: the middle estimate sits 1.8-fold (0.26 log units) above what was measured; low and high end bracket the measured number.
By their numbers in this assay, from the lowest: compounds 2 and 3 (each within the scatter of the next); then compound 1.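

In this assay, hydroxy in place of furan-2-yl gives no change at the digits printed from compound 2 to compound 3 (within the scatter), so a single oxygen can take the place of a five-membered aromatic ring at this carbon without a change that stands out from the scatter. Hydroxy in place of phenyl then gives a 3.3-fold lower number from compound 1 to compound 3 (0.52 log units; beyond the scatter), which means that the lower number seen earlier is not confined to furan-2-yl; among the three groups shown, phenyl alone stands apart, and a group need not carry a ring to reach the level of compound 2. Nothing measured here bears on why two groups so different in size give numbers within the scatter of each other.

From the compounds shown here alone, whether the number holds with a methoxy group, an amine or a carboxylic acid on this aromatic carbon remains open, as does what a plain hydrogen would give there. Going by these compounds, all three compounds share one core, so it also remains open whether hydroxy and furan-2-yl would again match each other on a different core.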